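Ethyl for methoxy on a weak sulfonamide series

The source may report more compounds than this note shows. Statements on the series, on what has been measured and on what is new or still open speak of the compounds shown alone.

Compound 1, `O=S(=O)(Nc1ccc2oc(-c3ccccc3)nc2c1)c1ccccc1O`, gives 85000 nM in an assay on cells for inhibition of HSP60/HSP10 (Homo sapiens), with a stated time of 60 min; a higher number here means a weaker inhibitor, a lower number a stronger inhibitor.
Compound 2, `O=S(=O)(Nc1ccc2oc(-c3ccccc3)nc2c1)c1ccc(O)cc1`, gives 88000 nM in this assay.
Compound 3, `COc1ccc(S(=O)(=O)Nc2ccc3oc(-c4ccccc4)nc3c2)cc1`, gives only a limit, > 100000 nM, in this assay.

The three compounds share one core and differ only in the ring attached to the sulfonyl sulfur. Moving the hydroxyl, a 1.0-fold higher number from compound 1 to compound 2 (0.02 log units; within the scatter), changes nothing beyond the scatter. Replacing the 2-hydroxyphenyl by 4-methoxyphenyl, an at least 1.1-fold higher number from compound 1 to compound 3 (0.07 log units; that floor lies within the scatter), and capping the hydroxyl with methyl, an at least 1.1-fold higher number from compound 2 to compound 3 (0.05 log units; that floor lies within the scatter), likewise give floors that sit within the scatter. Compound 3 therefore stands at the edge of what this assay reports, (the limit of > 100000 nM in this assay, at which 1 of the 3 values shown sits), with no number of its own.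

Compound 4, `CCc1ccc(S(=O)(=O)Nc2ccc3oc(-c4ccccc4)nc3c2)cc1`, differs from compound 3 by ethyl in place of methoxy on an aromatic carbon. Every measured step in this series was small, and none of them points to a direction for this change. Compound 4 is therefore expected to remain in the same weak region, and its estimated step is a number no higher from compound 3 to compound 4 (the limit leaves the size open). The estimate for compound 4 is 100000 nM, expected to lie between 45000 nM and 300000 nM, with a fair chance that the assay again reports only a limit.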

Compound 4, half-maximal inhibitory concentration: > 100000 nM
Compound 4 ended at the assay's limit; the forecaster's own chance of this, stated with the estimate: 55%; the middle value sits exactly at the limit.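

Compound 3 and compound 4 both stop at the reporting limit of this assay, so the step between them and its size cannot be read, and the swap of methoxy for ethyl has no measurable outcome here: the limit of > 100000 nM in this assay, at which 2 of the 4 values shown sit.

What compound 4 adds is a first ring in this set with no oxygen on it: the 4-ethylphenyl group carries a plain carbon chain where compound 1, compound 2 and compound 3 each have a hydroxyl or methoxy. Even so, the comparison gives only floors, an at least 1.1-fold higher number from compound 2 to compound 4 (0.05 log units; that floor lies within the scatter) and an at least 1.1-fold higher number from compound 1 to compound 4 (0.07 log units; that floor lies within the scatter), so compound 4 cannot be called weaker than either hydroxyl compound.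

An oxygen on this ring is therefore not shown to matter in either direction, since the ethyl ring, with no hydrogen-bond acceptor, gives no readable gain.

As far as these compounds go, how far compound 3 and compound 4 lie past the limit stays unknown, and with it any true difference between methoxy and ethyl. Also open, from the compounds shown here alone, is whether an amine, a carboxylic acid or a longer chain such as butyl, on an aromatic carbon para to a large group, would bring a value clearly below the limit.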